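Naphthyridinone amides against glioblastoma cells: a substituted aryl

This account rests on a few compounds, and the source may have more. Where it says the series, first, only, none or still open, it means among the compounds named here.

Measured so far:
compound 1, `Cn1ccc2c(Oc3ccc(NC(=O)c4cc5cccnc5n(-c5ccccc5)c4=O)cc3)ccnc21`: 5030 nM
compound 2, `Cn1ccc2c(Oc3ccc(NC(=O)c4cc5cccnc5n(-c5ccccc5)c4=O)cc3F)ccnc21`: 3590 nM

Compound 1, `Cn1ccc2c(Oc3ccc(NC(=O)c4cc5cccnc5n(-c5ccccc5)c4=O)cc3)ccnc21`, carries a phenyl on the aromatic nitrogen of the fused core and in a functional assay on U-87MG ATCC cells for antiproliferative activity against U-87 MG (Homo sapiens), read by MTT assay, with a stated time of 72 h (on this read-out higher numbers stand for weaker inhibition and lower numbers for stronger inhibition), compound 1 gives 5030 nM. Compound 2, `Cn1ccc2c(Oc3ccc(NC(=O)c4cc5cccnc5n(-c5ccccc5)c4=O)cc3F)ccnc21`, adds a fluoro on the central aryl ring, and in this assay compound 2 gives 3590 nM. The single step between them, a 1.4-fold lower number from compound 1 to compound 2 (0.15 log units; within the scatter), lies within the scatter, so compound 2 has the lowest of the two numbers shown without being separable from compound 1.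

Compound 3, `Cn1ccc2c(Oc3ccc(NC(=O)c4cc5cccnc5n(-c5ccc(C(F)(F)F)cc5Cl)c4=O)cc3F)ccnc21`, keeps that fluoro and changes the group on the aromatic nitrogen: 2-chloro-4-(trifluoromethyl)phenyl in place of phenyl on an aromatic nitrogen. Among the measured compounds shown here, no measured step touches this position; the only step in hand concerns the fluoro on the central ring and was within the scatter. There is therefore nothing to fix the size or direction of the step, and the estimate for compound 3 is centred close to compound 2 with a wide range.

Compound 3 is expected to give about 2000 nM, between 300 nM and 10000 nM. The step this implies, a 1.8-fold lower number from compound 2 to compound 3 (0.25 log units; within the scatter), is an estimate only.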

Compound 3, half-maximal inhibitory concentration: 10200 nM
For compound 3 the middle estimate is 5.1-fold (0.71 log units) below the measured one; the measured number lies above the stated range.
By their numbers in this assay, from the lowest: compounds 2 and 1 (each within the scatter of the next); then compound 3.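

The step of a 2.8-fold higher number from compound 2 to compound 3 (0.45 log units; beyond the scatter) in this assay shows that the group on the aromatic nitrogen can move this read-out beyond the scatter, though only modestly, and in the direction of a higher number, which stands for weaker inhibition. Among the compounds shown here, the earlier pair could not show this, since its only step concerned a fluoro on the central aryl ring and stayed within the scatter. The ring on the nitrogen remains a six-membered aromatic ring of carbon only, with no hydrogen-bond donors or acceptors on either group, so what differs is the chloro and the trifluoromethyl that arrive together, and no measurement shown here offers an explanation of the step.

From the compounds shown here alone, a single step cannot divide the change between those two substituents, so it remains open how a phenyl carrying only the chloro or only the trifluoromethyl would read. Also open, going by these compounds, is how this assay would respond to an amine or a carboxylic acid on that phenyl, or to a short alkyl chain in its place on the nitrogen.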